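A benzyl ester takes the place of trifluoromethyl

The compounds below may be only part of what the source reports. "The series", "measured", "known", "first", "only" and "open" are said of these compounds alone.

Compound 1 `COc1ccc(-c2nn(-c3ccccc3)cc2-c2nc3cc(F)ccc3[nH]2)cc1`: 1980 nM
Compound 2 `COc1ccc(-c2nn(-c3ccccc3)cc2-c2nc3cc(Cl)ccc3[nH]2)cc1`: 3130 nM
Compound 3 `COc1ccc(-c2nn(-c3ccccc3)cc2-c2nc3cc(C(F)(F)F)ccc3[nH]2)cc1`: 4820 nM
Compound 4 `COc1ccc(-c2nn(-c3ccccc3)cc2-c2nc3cc(C(=O)OCc4ccccc4)ccc3[nH]2)cc1`: not yet measured

These values come from a functional assay on A549 cells (Homo sapiens) for antiproliferative activity, read by MTT assay, with a stated time of 48 h; on this read-out higher numbers stand for weaker inhibition and lower numbers for stronger inhibition. Compound 3, at 4820 nM, stands within the scatter of compound 2, as a 1.5-fold higher number from compound 2 to compound 3 (0.19 log units; within the scatter) shows. It is separated from compound 1 only by a 2.4-fold higher number from compound 1 to compound 3 (0.39 log units; beyond the scatter).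

The next change is benzyloxycarbonyl in place of trifluoromethyl on an aromatic carbon. The closest evidence is the exchange of one small group for another, with a 1.6-fold higher number from compound 1 to compound 2 (0.20 log units; within the scatter) alongside the two steps above. None of these entering groups carries a ring, so they guide only loosely. A small step, possibly none beyond the scatter, is therefore expected in this assay. The expected step is a 1.1-fold higher number from compound 3 to compound 4 (0.06 log units; within the scatter). For compound 4 the estimated value is 5500 nM, with an expected range from 2000 nM to 15000 nM.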

Compound 4, half-maximal inhibitory concentration: 11900 nM
Beside the measured number, compound 4's estimate is 2.2-fold (0.34 log units) below it, and the stated range covers the measured number.
By their numbers in this assay, from the lowest: compounds 1, 2 and 3 (each within the scatter of the next, the first and the last beyond it); then compound 4.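

In this assay, within the data shown here, benzyloxycarbonyl is the first entering group with a ring, and it gives the weakest inhibition of the four compounds (a 2.5-fold higher number from compound 3 to compound 4 (0.39 log units; beyond the scatter)). The step grows against the two smaller halogens (a 3.8-fold higher number from compound 2 to compound 4 (0.58 log units; beyond the scatter); a 6.0-fold higher number from compound 1 to compound 4 (0.78 log units; beyond the scatter)), so this aromatic carbon does accept the larger ester, but with a loss beyond the scatter against every smaller group shown. No available measurement accounts for this loss. As far as these compounds go, what remains open is whether the benzyl ring or the ester carries the step; a methyl ester or a carboxylic acid at this place would separate the two.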